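Capping the phenol oxygen of compound 1 with butylcarbonyl

A few compounds are considered here, and "the series" means these few. Any claim that something is new, unique, unknown or untested is made for them only; others in the source may bear on it.

Measured so far in a functional assay on K562 cells (Homo sapiens) for cytotoxicity, read by MTT assay; on this read-out lower numbers stand for stronger inhibition and higher numbers for weaker inhibition:
compound 1 `COc1ccc(/C=C/C(=O)c2ccc(OC)c3c2OC(C)(C)C=C3)cc1O` gives 630 nM
compound 2 `COc1ccc(/C=C/C(=O)c2ccc(OC)c3c2OC(C)(C)C=C3)cc1OCCO` gives 8750 nM

Compound 1 holds the lowest of the two numbers in this assay. Compound 3 `CCCCC(=O)Oc1cc(/C=C/C(=O)c2ccc(OC)c3c2OC(C)(C)C=C3)ccc1OC` differs from compound 1 by butylcarbonyl in place of hydrogen on an oxygen on an aromatic ring. Among the compounds with values here, the one step that bears on this change is a 14-fold higher number from compound 1 to compound 2 (1.14 log units; beyond the scatter), where the same oxygen also lost its hydrogen to another group. A similar loss is therefore expected here, though the size is uncertain. For compound 3 the expected step in this assay is a 4.8-fold higher number from compound 1 to compound 3 (0.68 log units; beyond the scatter). Compound 3 is thus estimated at 3000 nM (range 1000 nM to 9000 nM).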

Compound 3, half-maximal inhibitory concentration: 240 nM
Compound 3: middle estimate off by 13-fold (1.10 log units), on the high side, and the stated range ends above it.
By their numbers in this assay, from the lowest: compound 3; then compound 1; then compound 2.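

In this assay, replacing the hydrogen on this oxygen does not by itself raise the number: butylcarbonyl gives a 2.6-fold lower number from compound 1 to compound 3 (0.42 log units; beyond the scatter) and so runs opposite to the 2-hydroxyethyl step. Exchanging 2-hydroxyethyl for butylcarbonyl on the same oxygen gives a 36-fold lower number from compound 2 to compound 3 (1.56 log units; beyond the scatter), so the outcome here depends on which group enters. Nothing on hand explains this difference between the two groups.

Still open, as far as these compounds go, is whether the carbonyl or the butyl chain carries the gain. An acetyl group, a longer acyl chain or a plain butyl ether on this oxygen would separate the two.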